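A few compounds are considered here, and "the series" means these few. Any claim that something is new, unique, unknown or untested is made for them only; others in the source may bear on it.

Working notes on the series. Compound 1 `COc1cc(-c2nnc3n2NC(c2ccco2)C(C(=O)c2ccccc2F)S3)cc(OC)c1OC` reaches only a limit in a functional assay on PC-3 cells (Homo sapiens) for cytotoxicity, read by MTT assay, with a stated time of 48 h; a higher number here means a weaker inhibitor, a lower number a stronger inhibitor: its value of > 100000 nM is a limit of the assay, not a number. Compound 2 `COc1cc(-c2nnc3n2NC(c2ccco2)C(C(=O)c2ccc(O)cc2)S3)cc(OC)c1OC` gives 38300 nM in this assay, and compound 3 `COc1cc(-c2nnc3n2NC(c2ccco2)C(C(=O)c2ccc(C(F)(F)F)cc2)S3)cc(OC)c1OC` gives 77500 nM. The measured steps run an at least 2.6-fold lower number from compound 1 to compound 2 (0.41 log units; beyond the scatter), an at least 1.2-fold lower number from compound 1 to compound 3 (0.11 log units; that floor lies within the scatter) and a 2.0-fold higher number from compound 2 to compound 3 (0.31 log units; beyond the scatter); the floor of the first two rests on (the limit of > 100000 nM in this assay, at which 1 of the 3 values shown sits). Compound 4 `COc1cc(-c2nnc3n2NC(c2ccco2)C(C(=O)c2ccc(-c4ccccc4)cc2)S3)cc(OC)c1OC` differs from compound 1 by 4-phenylphenyl in place of 2-fluorophenyl on a carbonyl carbon. Both measured steps away from compound 1 lowered the number, one at least modestly and one only to within the scatter, so a lower number than the limit of compound 1 is expected here too, of modest size at most. Compound 4 is therefore estimated at 65000 nM, with a range of 20000 nM to 150000 nM. The expected step is an at least 1.5-fold lower number from compound 1 to compound 4 (0.18 log units; that floor lies within the scatter).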

Compound 4, half-maximal inhibitory concentration: 45900 nM
For compound 4 the middle estimate is 1.4-fold (0.15 log units) above the measured one; the range from low to high includes it.
By their numbers in this assay, from the lowest: compounds 2, 4 and 3 (each within the scatter of the next, the first and the last beyond it). At a limit, above all of these: compound 1.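

In this assay, 4-phenylphenyl on the carbonyl carbon gives an at least 2.1-fold lower number from compound 1 to compound 4 (0.33 log units; beyond the scatter), so a second aromatic ring still leaves a measurable number where 2-fluorophenyl does not. That step is only a floor, resting on a limit of the assay: the limit of > 100000 nM in this assay, at which 1 of the 4 values shown sits.

With the ring in place, the change in the substituent on the aromatic carbon gives a 1.7-fold lower number from compound 3 to compound 4 (0.23 log units; within the scatter) and a 1.2-fold higher number from compound 2 to compound 4 (0.08 log units; within the scatter), so phenyl does not separate from trifluoromethyl or hydroxy there.

Whether an amine or a carboxylic acid on that aromatic carbon would move the number beyond the scatter of these compounds remains open.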